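This account rests on a few compounds, and the source may have more. Where it says the series, first, only, none or still open, it means among the compounds named here.

Measured so far in a functional assay on PC-3 cells (Homo sapiens) for cytotoxicity, read by MTT assay, with a stated time of 72 h; a lower number here means a stronger inhibitor, a higher number a weaker inhibitor:
compound 1 `Cc1cc(=O)n(-c2cccc(F)c2)nc1C(=O)Nc1ccc(Oc2ncnc3c2ccn3C)c(F)c1` — 8990 nM
compound 2 `Cc1cc(=O)n(-c2ccccc2C(F)(F)F)nc1C(=O)Nc1ccc(Oc2ncnc3c2ccn3C)c(F)c1` — 25900 nM

Within the data shown here, compound 2 stands at the higher of the two numbers in this assay; the one measured step, a 2.9-fold higher number from compound 1 to compound 2 (0.46 log units; beyond the scatter), sets it apart. Compound 3 `Cc1cc(=O)n(-c2ccccc2Cl)nc1C(=O)Nc1ccc(Oc2ncnc3c2ccn3C)c(F)c1` is not yet measured. It differs from compound 2 by chloro in place of trifluoromethyl on an aromatic carbon. Among the measured compounds shown here, the single measured step exchanges the whole aryl on the aromatic nitrogen, moving a fluoro from one position to a trifluoromethyl at another, and so bears on the step to compound 3 only loosely. For the measured compounds named here, no measured pair swaps one group for another at the same place, and no precedent for chloro in place of trifluoromethyl is at hand. A modest movement of uncertain direction is therefore expected, described as a 1.6-fold lower number from compound 2 to compound 3 (0.21 log units; within the scatter). For compound 3 the estimate in this assay is 16000 nM, within a range from 5000 nM to 50000 nM.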

Compound 3, half-maximal inhibitory concentration: > 60000 nM
Compound 3: a limit, no number (the forecaster's own chance of this, stated with the estimate: 10%); at least 3.7-fold (0.57 log units) between middle value and limit.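

Compound 3 reads as a limit of the assay, not a number, in this assay: the limit of > 60000 nM in this assay, at which 1 of the 3 values shown sits.

Among these compounds, the first exchange at a single place, chloro in place of trifluoromethyl on an aromatic carbon ortho to a large group, gives an at least 2.3-fold higher number from compound 2 to compound 3 (0.36 log units; beyond the scatter), so the chloro analogue does not recover activity at this position. Against the 3-fluorophenyl group the 2-chlorophenyl group gives an at least 6.6-fold higher number from compound 1 to compound 3 (0.82 log units; beyond the scatter), and among these three compounds both 2-substituted phenyl groups sit on the weaker side of compound 1, with none going against this.

On these data alone, how far compound 3 lies past its limit stays open, so both steps are lower bounds only. Also open, as far as these compounds go, is whether a 3-chlorophenyl group, an unsubstituted phenyl or an aminophenyl on the aromatic nitrogen would give a lower number than compound 1.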